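Adding an ethyl to the amine of compound 2

A few compounds are considered here, and "the series" means these few. Any claim that something is new, unique, unknown or untested is made for them only; others in the source may bear on it.

- compound 1 `COc1ccc(C(=O)c2ccc3c(c2)C=CC(C)(C)O3)c(NC(=O)CN)c1`: 490 nM
- compound 2 `C=C(c1ccc(OC)cc1NC(=O)CN)c1ccc(OC)c2c1C=CC(C)(C)O2`: 520 nM
- compound 3 `C=C(c1cc(OC)c(OC)c(OC)c1)c1ccc(OC)cc1NC(=O)CN`: 60 nM

In a functional assay on HCT-8 cells (Homo sapiens) for antiproliferative activity, read by MTT assay, with a stated time of 48 h (on this read-out higher numbers stand for weaker inhibition and lower numbers for stronger inhibition), compound 2 gives 520 nM and compound 1 gives 490 nM, so these two stand level within the usual scatter. Compound 3 gives 60 nM, a clearly lower number that lies beyond the scatter from compound 2 and means stronger inhibition.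

Compound 4 `C=C(c1ccc(OC)cc1NC(=O)CNCC)c1ccc(OC)c2c1C=CC(C)(C)O2` is compound 2 with one change: ethyl in place of hydrogen on an amine nitrogen. For the measured compounds named here, no pair of measured compounds shows what this kind of change does, so any expectation starts from compound 2 at 520 nM and remains uncertain. In this assay a modest loss of inhibition is expected, only a little beyond the scatter, though no change at all remains possible. The estimated size of this move is a 1.9-fold higher number from compound 2 to compound 4 (0.28 log units; within the scatter). The expected value for compound 4 is 1000 nM, with an estimated range of 300 nM to 3500 nM.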

Compound 4, half-maximal inhibitory concentration: 3050 nM
Compound 4: middle estimate off by 3.1-fold (0.48 log units), on the low side, within the range that was stated.
By their numbers in this assay, from the lowest: compound 3; then compounds 1 and 2 (each within the scatter of the next); then compound 4.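

Ethyl in place of hydrogen on this amine nitrogen weakens inhibition clearly: in this assay the change gives a 5.9-fold higher number from compound 2 to compound 4 (0.77 log units; beyond the scatter), so this nitrogen does not accept the added ethyl without loss. For the compounds shown here, this is the first view of the position, since compounds 1, 2 and 3 all carry the same free amino group and differ from each other elsewhere, which says nothing about changes at the amine itself. Nothing available explains why the ethyl lowers activity.

The compounds shown leave open whether a smaller methyl on this nitrogen would lose less, or a longer propyl chain more. They also leave open whether the same ethyl would weaken compound 3 to a similar degree, given that its core differs from that of compound 2.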